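The source may hold more compounds than are shown below. What is called first, only, known or untested is meant among the compounds shown, and "the series" means these compounds.

Compound 1 `O=C1C2=C(C(=O)c3ncccc31)C1(CS2)NC(=O)N(c2ccc(Cl)cc2)C1=O` and compound 2 `CCCCCc1ccc(N2C(=O)NC3(CSC4=C3C(=O)c3ncccc3C4=O)C2=O)cc1` share one core and differ only in the group on the outer aromatic ring. In a functional assay on ACHN cells (Homo sapiens) for antiproliferative activity, read by MTT assay, with a stated time of 96 h (on this read-out higher numbers stand for weaker inhibition and lower numbers for stronger inhibition), compound 1 gives 4 nM, while compound 2 gives 250 nM. Among the compounds with values here, that single change, pentyl in place of chloro on an aromatic carbon, brings a 63-fold higher number from compound 1 to compound 2 (1.80 log units; beyond the scatter), so compound 2 stands highest of the two numbers, with compound 1 as its only neighbour. Compound 3 `O=C1C2=C(C(=O)c3ncccc31)C1(CS2)NC(=O)N(c2ccc([N+](=O)[O-])cc2)C1=O` is the next step from compound 2: nitro in place of pentyl on an aromatic carbon. Within the data shown here, the one measured step that bears on this is the one from compound 1 to compound 2, which removed a small group and added the pentyl chain and was large; here the pentyl leaves again. Because a 63-fold higher number from compound 1 to compound 2 (1.80 log units; beyond the scatter) was large, the reverse move is expected to give a large step toward lower numbers, a 25-fold lower number from compound 2 to compound 3 (1.40 log units; beyond the scatter). Compound 3 is therefore estimated at 10 nM in this assay, within 2 nM to 60 nM.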

Compound 3, half-maximal inhibitory concentration: 100 nM
For compound 3 the middle estimate is 10-fold (1.00 log units) below the measured one, and the stated range ends below it.
By their numbers in this assay, from the lowest: compound 1; then compound 3; then compound 2.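

Removing the pentyl chain from this place on the outer aromatic ring does little by itself: nitro in its place gives only a 2.5-fold lower number from compound 2 to compound 3 (0.40 log units; beyond the scatter) and leaves compound 3 far from compound 1. In this assay the change from chloro to nitro at the same place gives a 25-fold higher number from compound 1 to compound 3 (1.40 log units; beyond the scatter) even though neither group is the pentyl chain, so the read-out depends on which group sits here and not only on the pentyl chain being gone. Nothing given here explains this order of the three groups.

With only chloro, nitro and pentyl shown at this place, it stays open where fluoro, bromo, methoxy, an amine or a carboxylic acid would fall. A shorter chain such as methyl or ethyl is equally open, so the compounds shown cannot tell whether the number climbs gradually with chain length.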